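A few compounds are considered here, and "the series" means these few. Any claim that something is new, unique, unknown or untested is made for them only; others in the source may bear on it.

Measured compounds:
compound 1 `COc1ccc(C2CC(c3ccc(Cl)cc3)=NN2c2ccc(-c3ccccc3)nn2)c(OC)c1` — > 100000 nM in a functional assay on HepG2 cells (Homo sapiens) for antiproliferative activity, read by MTT assay, with a stated time of 24 h; a lower number here means a stronger inhibitor, a higher number a weaker inhibitor
compound 2 `COc1ccc(C2=NN(c3ccc(-c4ccccc4)nn3)C(c3ccccc3)C2)cc1` — > 100000 nM
compound 3 `COc1ccc(C2=NN(c3ccc(-c4ccccc4)nn3)C(c3ccc(F)cc3)C2)cc1` — 9160 nM

Compound 1 sits at a limit of this assay, not a number. Compound 2 likewise sits at a limit. Compound 3 is the only one of the three that gives an actual number, the other two values being limits; it therefore stands on its own in this assay.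

For the measured compounds named here, the one measured step is an at least 10-fold lower number from compound 2 to compound 3 (1.03 log units; beyond the scatter), a large change that arises from a small substitution on an aromatic carbon, against the limit of > 100000 nM in this assay, at which 2 of the 3 values shown sit, as the backdrop.

Compound 4 `COc1ccc(C2=NN(c3ccc(-c4ccccc4)nn3)C(c3ccc(OC)cc3OC)C2)cc1` differs from compound 3 by 2,4-dimethoxyphenyl in place of 4-fluorophenyl on a saturated ring carbon. Going by the values given here, no measured step covers this change directly. The step from compound 2 to compound 3 shows that the group on the saturated ring carbon matters in this assay, so a change of comparable or larger size is plausible here, in either direction. Compound 1 also carries a 2,4-dimethoxyphenyl on its saturated ring carbon and sits at a limit, though it differs from compound 4 in a second place as well.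

Compound 4 is expected to be weaker, with the estimate 30000 nM (range 6000 nM to 150000 nM), a step of a 3.3-fold higher number from compound 3 to compound 4 (0.52 log units; beyond the scatter), with a real chance that only a limit is reported.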

Compound 4, half-maximal inhibitory concentration: > 100000 nM
Compound 4 ended at the assay's limit; the forecaster's own chance of this, stated with the estimate: 40%; middle value at least 3.3-fold (0.52 log units) from the limit.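

In this assay, 2,4-dimethoxyphenyl in place of 4-fluorophenyl on the saturated ring carbon gives an at least 10-fold higher number from compound 3 to compound 4 (1.03 log units; beyond the scatter), so this larger aromatic group does not keep the measurable activity of compound 3. Within the compounds shown, a readable number at this position occurs only with 4-fluorophenyl, while both phenyl and 2,4-dimethoxyphenyl end at the limit of the assay. The steps to compound 4 from compound 2 and from compound 1 cannot be read, because both ends of each step are limits, which leaves the ordering among these compounds unknown: the limit of > 100000 nM in this assay, at which 3 of the 4 values shown sit.

Still open, going by these compounds, is whether the readable activity of compound 3, at 9160 nM, depends on fluoro specifically or would also appear with another single group on the phenyl ring at the saturated ring carbon, such as an amine, a carboxylic acid or one methoxy. The compounds shown also leave open whether dropping one of the two methoxy groups of compound 4 would bring a readable number back.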